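Cyclopentyl in place of benzyl on the shared chain

A few compounds are considered here, and "the series" means these few. Any claim that something is new, unique, unknown or untested is made for them only; others in the source may bear on it.

Compound 2 `O=C(CCCc1ccccc1)NNc1c(Cl)cncc1Cl` and compound 1 `O=C(CCc1ccc(F)cc1)NNc1c(Cl)cncc1Cl` share the same core and differ only in the group on a saturated chain carbon, two bonds along the chain from a carbonyl carbon. In a functional assay on HEK293 cells for antagonist activity at P2X purinoceptor 7 (Homo sapiens), read by fluorescence, with a stated time of 2 h (a lower number here means a stronger inhibitor, a higher number a weaker inhibitor), compound 1 gives 900 nM, and in this assay compound 2 gives 770 nM. Among the compounds with values here, the step of a 1.2-fold lower number from compound 1 to compound 2 (0.07 log units; within the scatter) is the only measured step available, and it sits at the same place as the change considered here. Within the data shown here, compound 2 holds the lowest of the two numbers, with compound 1 as its only neighbour and the two within the scatter of one another.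

Compound 3 `O=C(CCC1CCCC1)NNc1c(Cl)cncc1Cl` arises from compound 2 by cyclopentyl in place of benzyl on a saturated chain carbon, two bonds along the chain from a carbonyl carbon. Among the measured compounds shown here, the one step that bears on this place, a 1.2-fold lower number from compound 1 to compound 2 (0.07 log units; within the scatter), lay within the scatter, but it does not cover the exchange of an aromatic ring for a non-aromatic one. The step of a 1.8-fold higher number from compound 2 to compound 3 (0.26 log units; within the scatter) is therefore expected to be modest, leaning toward a higher number. Compound 3 is estimated at 1400 nM in this assay, with a range from 500 nM to 4000 nM.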

Compound 3, half-maximal inhibitory concentration: 380 nM
Beside the measured number, compound 3's estimate is 3.7-fold (0.57 log units) above it; measured number outside the range, below it.
By their numbers in this assay, from the lowest: compound 3; then compounds 2 and 1 (each within the scatter of the next).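

With this step, the position shows its first change beyond the scatter. In this assay, replacing the aromatic ring with a non-aromatic one gives a 2.0-fold lower number from compound 2 to compound 3 (0.31 log units; beyond the scatter) and, measured against the 4-fluorophenyl compound, a 2.4-fold lower number from compound 1 to compound 3 (0.37 log units; beyond the scatter), whereas the earlier exchange of 4-fluorophenyl for benzyl gave only a 1.2-fold lower number from compound 1 to compound 2 (0.07 log units; within the scatter). Among these three compounds, therefore, an aromatic ring on this saturated chain carbon is not needed for activity, and the modest lower number comes with cyclopentyl, but nothing available gives a reason for this result.

The exchange alters ring size, aromatic character and the count of heavy atoms together, so the compounds shown leave open which of these goes with the lower number. They also leave open how a cyclohexyl ring, a longer straight alkyl chain, or an amine or carboxylic acid at this place would read, and therefore whether cyclopentyl marks a local optimum or only one point on a continuing trend.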